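A few compounds are considered here, and "the series" means these few. Any claim that something is new, unique, unknown or untested is made for them only; others in the source may bear on it.

Compound 2 `O=C(c1ccccc1)c1nc2sc3c(c2c2n[nH]c(=S)n12)CCCC3` gives 0% in an assay on isolated protein for inhibition of adenosine receptor A1 (Rattus norvegicus), tested at 1 uM (a higher number here means more inhibition at the concentration tested (going by the name of the read-out), a lower number less inhibition), the lowest of the two numbers seen so far; its nearest neighbour, compound 1 `Cc1nc2sc3c(c2c2n[nH]c(=S)n12)CCCC3`, gives 26%. Among the measured compounds shown here, the only measured step that touches compound 2 is a number 26 percentage points lower from compound 1 to compound 2 (beyond the scatter), the swap of benzoyl for methyl on the shared core.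

Compound 3 `S=c1[nH]nc2c3c4c(sc3nc(-c3ccncc3)n12)CCCC4` differs from compound 2 in one place: pyridin-4-yl in place of benzoyl on an aromatic carbon. The new group sits on an aromatic carbon of the core, between two ring nitrogen atoms, where the benzoyl stood. For the measured compounds named here, no measured step shows what a pyridin-4-yl does here, and the benzoyl step only shows that a large group at this position lowered inhibition. The estimate therefore leans on a wide range and expects compound 3 to stay low, near 15% (0% to 45%), with an expected step of a number 15 percentage points higher from compound 2 to compound 3 (beyond the scatter).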

Compound 3, a percentage reported as inhibition, at one concentration (the size of the read-out at that concentration, not a potency): 0%
For compound 3 the middle estimate is 15 percentage points above the measured one, within the range that was stated.
By their numbers in this assay, from the lowest: compounds 2 and 3 (each within the scatter of the next); then compound 1.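

In this assay the swap of benzoyl for pyridin-4-yl brings no change at the digits printed from compound 2 to compound 3 (within the scatter) and so a second group carrying a six-membered aromatic ring on this aromatic carbon does not restore what the methyl group gives. Measured against that methyl group, pyridin-4-yl gives a number 26 percentage points lower from compound 1 to compound 3 (beyond the scatter) and this matches the direction of benzoyl in a number 26 percentage points lower from compound 1 to compound 2 (beyond the scatter) so the drop does not depend on the carbonyl of benzoyl, which pyridin-4-yl lacks.

Still open, going by these compounds, is whether hydrogen, ethyl, an amine or a plain phenyl on this carbon would keep the inhibition seen with the methyl group of compound 1, or raise it. No measurement shown here explains why both ring-bearing groups give less inhibition than methyl.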